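Hydrazide and pyrazole variants at the phenoxyacetyl carbonyl

The source may report more compounds than this note shows. Statements on the series, on what has been measured and on what is new or still open speak of the compounds shown alone.

Working notes on the series. Three compounds carry the shared core of compound 1 `CCOC(=O)C1=C(C)NC(C)=C(C(=O)OCC)C1c1ccc(OCC(=O)NNC(=O)c2ccccc2)cc1` and differ only in the group on the carbonyl carbon of the phenoxyacetyl arm. In a functional assay on the whole organism (strain Wistar) for inhibition, with Rattus norvegicus as the target, read by paw edema, with stated times of 30 min and 3 h, at a dose of 20 mg/kg (on this read-out lower numbers stand for less inhibition and higher numbers for more inhibition at the one dose given (going by the name of the read-out)), compound 1 gives 44.9%. Compound 2 `CCOC(=O)C1=C(C)NC(C)=C(C(=O)OCC)C1c1ccc(OCC(=O)NNC(=O)c2cccs2)cc1` gives 61.1% in this assay, and compound 3 `CCOC(=O)C1=C(C)NC(C)=C(C(=O)OCC)C1c1ccc(OCC(=O)n2nc(C)cc2C)cc1` gives 48.5%. Compound 3 thus stands second of the three numbers: its value is close to that of compound 1 and well short of that of compound 2. The measured steps are a number 16.2 percentage points higher from compound 1 to compound 2 (beyond the scatter), a number 3.6 percentage points higher from compound 1 to compound 3 (within the scatter) and a number 12.6 percentage points lower from compound 2 to compound 3 (beyond the scatter).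

Compound 4 `CCOC(=O)C1=C(C)NC(C)=C(C(=O)OCC)C1c1ccc(OCC(=O)NN2C(=O)c3ccccc3C2=O)cc1` is not yet measured. The change from compound 3 is a group of 12 heavy atoms (8 carbon, 2 nitrogen, 2 oxygen; one five-membered non-aromatic ring with 1 hetero atom, one six-membered aromatic ring of carbon only) in place of a group of 7 heavy atoms (5 carbon, 2 nitrogen; one five-membered aromatic ring with 2 hetero atoms), on a carbonyl carbon. The entering group, like those of compound 1 and compound 2, carries one hydrogen-bond donor, whereas the group that leaves carries none. The two steps that bear on this change are the ones leading into compound 3: one within the scatter, one a modest drop. A return to a donor-bearing group is therefore expected to give at most a small rise in this assay, within or just beyond the scatter, so the expected step is a number 1.5 percentage points higher from compound 3 to compound 4 (within the scatter). Compound 4 is estimated at 50%, with a range from 38% to 62%.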

Compound 4, a percentage reported as inhibition, in the whole organism at one dose (the size of the read-out at that dose, not a potency): 59.3%
Compound 4: middle estimate off by 9.3 percentage points, on the low side, and the stated range covers the measured number.
By their numbers in this assay, from the lowest: compounds 1 and 3 (each within the scatter of the next); then compounds 4 and 2 (each within the scatter of the next).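

Compound 4 shows that a high reading at this position does not depend on thiophen-2-yl: the group of compound 4, with its five-membered non-aromatic ring and six-membered aromatic ring, gives a number 10.8 percentage points higher from compound 3 to compound 4 (beyond the scatter) and a number 14.4 percentage points higher from compound 1 to compound 4 (beyond the scatter), while the comparison with the thiophene hydrazide gives a number 1.8 percentage points lower from compound 2 to compound 4 (within the scatter). In this assay, the hydrogen-bond donor does not sort the series on its own, since compound 4 and compound 2 carry one and sit at the upper level, whereas compound 1 also carries one and still gives a number 3.6 percentage points higher from compound 1 to compound 3 (within the scatter) against the donor-free pyrazole. No measurement on hand bears on why these groups differ at this position.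

The compounds shown leave open whether the upper level extends to smaller or simpler groups on this carbonyl carbon, such as a plain amine, a carboxylic acid or a piperidine ring. They also leave open whether a saturated five-membered ring without the fused six-membered aromatic ring, such as a pyrrolidine-2,5-dione on the amide-type nitrogen, would keep the reading of compound 4.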